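The compounds below may be only part of what the source reports. "The series", "measured", "known", "first", "only" and "open" are said of these compounds alone.

Measured compounds in a toxicity assay on HT-29 cells (Homo sapiens) for cytotoxicity; on this read-out lower numbers stand for higher toxicity in this test and higher numbers for lower toxicity in this test:
compound 1 `CC(C)CCn1nc(C(=O)N[C@H]2COc3ccccc3N(C)C2=S)nc1Cc1ccccc1`: > 100000 nM
compound 2 `CN1C(=S)[C@@H](NC(=O)c2nc(Cc3ccccc3)n(CCCCCC#N)n2)COc2ccccc21`: > 100000 nM
compound 3 `CN1C(=S)[C@@H](NC(=O)c2nc(Cc3ccccc3)n(C3CCCC3)n2)COc2ccccc21`: > 100000 nM

In this assay compound 1 gives > 100000 nM, which is a limit of the assay and not a number. For compound 2 the value > 100000 nM is likewise only a limit. For compound 3 the value > 100000 nM is also a limit. Compound 1 therefore stands nowhere definite; every value in the set sits at the limit of > 100000 nM in this assay, at which 3 of the 3 values shown sit.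

The unmeasured compound 4 `CN1C(=S)[C@@H](NC(=O)c2nc(Cc3ccccc3)n(C3CCOCC3)n2)COc2ccccc21` differs from compound 1 by oxan-4-yl in place of isopentyl on an aromatic nitrogen. The measured steps touching the same aromatic nitrogen are a step that the two limits leave unreadable from compound 1 to compound 3 and a step that the two limits leave unreadable from compound 2 to compound 3, and the chain change a step that the two limits leave unreadable from compound 1 to compound 2 is unreadable as well. None of them gives a readable size, so no direction can be drawn for compound 4 in this assay beyond noting that every change made so far on this position left the value at the limit.

Compound 4 is therefore expected to remain near 100000 nM, within 40000 nM to 300000 nM. The step of a number no higher from compound 1 to compound 4 (the limit leaves the size open) is expected to be none beyond the scatter.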

Compound 4, half-maximal cytotoxic concentration: > 100000 nM
Compound 4: no number, only a limit; the forecaster's own chance of this, stated with the estimate: 85%; the middle value lies on the limit itself.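

In this assay compound 4 gives > 100000 nM, which is a limit and not a number. Its steps to compound 1, compound 2 and compound 3 cannot be read. The compounds shown leave open what group on the aromatic nitrogen, if any, would give a measurable value in this assay.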